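Hydroxy to fluoro on the branched chain: antiproliferative notes

The source may report more compounds than this note shows. Statements on the series, on what has been measured and on what is new or still open speak of the compounds shown alone.

The series is read in a functional assay on SW-620 cells (Homo sapiens) for antiproliferative activity, read by MTT assay, with a stated time of 72 h; on this read-out higher numbers stand for weaker inhibition and lower numbers for stronger inhibition. Compound 1 `Cc1c(C=C(CO)CO)n(C)c(=O)[nH]c1=O` gives > 100000 nM in this assay, which is a limit of the assay and not a number. Compound 2 `COc1nc(CC(O)(CO)CO)c(C)c(OC)n1` likewise gives only a limit, > 100000 nM. Compound 3 `COc1nc(CC(O)(COC(C)=O)COC(C)=O)c(C)c(OC)n1` also sits at a limit, > 100000 nM. Compound 3 therefore stands where every shown value stands, at the limit of > 100000 nM in this assay, at which 3 of the 3 values shown sit, with no number to set it apart from compounds 1 and 2.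

Compound 4 `COc1nc(CC(F)(COC(C)=O)COC(C)=O)c(C)c(OC)n1` differs from compound 3 by fluoro in place of hydroxy on a saturated chain carbon bound to three saturated chain carbons. Among the compounds with values here, no step between measured compounds exists here against which this change could be sized. Given that compound 3 sits at the limit > 100000 nM, no step beyond the usual scatter is expected. For compound 4 the expected step is a step that the limit leaves unreadable from compound 3 to compound 4. Compound 4 is estimated at about 150000 nM, within 50000 nM to 500000 nM, and most likely reported again only as a limit.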

Compound 4, half-maximal inhibitory concentration: > 100000 nM
Compound 4: a limit, no number (the forecaster's own chance of this, stated with the estimate: 85%); the middle value does not contradict the limit.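

The step from compound 3 to compound 4, fluoro in place of hydroxy, cannot be read, because both compounds give a limit and not a number: the limit of > 100000 nM in this assay, at which 4 of the 4 values shown sit. The compounds shown leave open whether any change to the branched chain or the shared core yields a measurable value.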